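A few compounds are considered here, and "the series" means these few. Any claim that something is new, unique, unknown or untested is made for them only; others in the source may bear on it.

Measured in a functional assay on DU-145 cells (Homo sapiens) for inhibition, read by trypan blue exclusion, with a stated time of 96 h; a higher number here means a weaker inhibitor of growth, a lower number a stronger inhibitor of growth:
- Compound 1 `Cc1ccc(CS/C(=C/c2ccccc2F)C(=O)c2ccc(Cl)cc2)cc1`: 10000 nM
- Compound 2 `Cc1ccc(CS/C(=C/c2ccccc2Br)C(=O)c2ccc(Cl)cc2)cc1`: 10000 nM

On these numbers, compound 2 stands level with compound 1. Compound 3 `Cc1ccc(CS/C(=C/c2cccc(Cl)c2Cl)C(=O)c2ccc(Cl)cc2)cc1` changes one group of compound 2: 2,3-dichlorophenyl in place of 2-bromophenyl on a double-bonded chain carbon bound to a double-bonded chain carbon. In words, 2,3-dichlorophenyl comes in place of 2-bromophenyl on a double-bonded chain carbon bound to a double-bonded chain carbon. For the measured compounds named here, only one measured step bears on this, the swap of bromo for fluoro on an aromatic carbon: no change at the digits printed from compound 1 to compound 2 (within the scatter). That is thin evidence, but it gives no reason to expect a shift beyond the scatter in this assay. The expected step is no change at the digits printed from compound 2 to compound 3 (within the scatter). The estimate for compound 3 is 10000 nM, within an expected range of 4000 nM to 25000 nM.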

Compound 3, concentration for 50% growth inhibition: 25000 nM
Compound 3: the middle estimate sits 2.5-fold (0.40 log units) below what was measured; the measured number falls inside the stated range.
By their numbers in this assay, from the lowest: compounds 1 and 2 (each within the scatter of the next); then compound 3.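

In this assay the aryl group on this double-bonded chain carbon turns out to matter: 2,3-dichlorophenyl gives a 2.5-fold higher number from compound 2 to compound 3 (0.40 log units; beyond the scatter) and a 2.5-fold higher number from compound 1 to compound 3 (0.40 log units; beyond the scatter) as well, a modest move toward weaker growth inhibition. For the compounds shown here, the earlier swap of fluoro and bromo showed no such movement, so this is the first sign of a response at this place. Nothing available gives a reason for the shift.

As far as these compounds go, whether the number of chlorines or their placement on the ring carries the step stays open, since 2,3-dichlorophenyl changes both at once. From the compounds shown here alone, how an amine or a methoxy group on this ring would read also remains open.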